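Methyl for Phenyl on an Aromatic Nitrogen: Series Notes

The source may report more compounds than this note shows. Statements on the series, on what has been measured and on what is new or still open speak of the compounds shown alone.

Compound 2 `O=C(CSc1nnnn1-c1ccccc1)N/N=c1/scc(-c2ccccc2)n1-c1ccccc1` is the reference here; in a functional assay on C6 cells (Rattus norvegicus) for cytotoxicity, read by MTT assay, with a stated time of 24 h (a lower number here means a stronger inhibitor, a higher number a weaker inhibitor), compound 2 gives 8.3 ug/mL. Compound 1 `Cn1nnnc1SCC(=O)N/N=c1/scc(-c2ccc(C#N)cc2)n1-c1ccccc1` gives 23.3 ug/mL in this assay. Compound 3 `N#Cc1ccc(-c2cs/c(=N/NC(=O)CSc3nnnn3-c3ccccc3)n2-c2ccccc2)cc1` gives > 200 ug/mL in this assay, which is a limit of the assay and not a number. Compound 2 and compound 3 differ by hydrogen in place of cyano on an aromatic carbon, with an at least 24-fold higher number from compound 2 to compound 3 (1.38 log units; beyond the scatter). Compound 4 `Cn1nnnc1SCC(=O)N/N=c1/scc(-c2ccccc2)n1-c1ccccc1` is not yet measured; it differs from compound 2 by methyl in place of phenyl on an aromatic nitrogen. The same change, (methyl in place of phenyl on an aromatic nitrogen), gave an at least 8.5-fold lower number from compound 3 to compound 1 (0.93 log units; beyond the scatter), and the place is the same word for word in both; the cores differ by hydrogen in place of cyano on an aromatic carbon. That earlier step is bounded on one side only because of the limit of > 200 ug/mL in this assay, at which 1 of the 3 values shown sits. The expected step from compound 2 to compound 4 in this assay is a 1.7-fold lower number from compound 2 to compound 4 (0.22 log units; within the scatter). Compound 4 is estimated at 5 ug/mL in this assay, between 1.5 ug/mL and 16 ug/mL.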

Compound 4, half-maximal inhibitory concentration: 67.7 ug/mL
Compound 4: the middle estimate sits 14-fold (1.13 log units) below what was measured; measured number above the stated range.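

In this assay, methyl in place of phenyl on the aromatic nitrogen gives an 8.2-fold higher number from compound 2 to compound 4 (0.91 log units; beyond the scatter), and this runs opposite to the step for the same change on the core carrying the nitrile: the same change on two cores in this assay, an at least 8.5-fold lower number (0.93 log units; beyond the scatter) from compound 3 to compound 1 and an 8.2-fold higher number (0.91 log units; beyond the scatter) from compound 2 to compound 4, at least 70-fold (1.84 log units) apart, beyond the scatter of two such steps

The nitrile step also depends on the group on that nitrogen, with hydrogen in place of cyano on an aromatic carbon giving a 2.9-fold higher number from compound 1 to compound 4 (0.46 log units; beyond the scatter): the same change on two cores in this assay, an at least 24-fold higher number (1.38 log units; beyond the scatter) from compound 2 to compound 3 and a 2.9-fold lower number (0.46 log units; beyond the scatter) from compound 4 to compound 1, at least 70-fold (1.84 log units) apart, beyond the scatter of two such steps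

The change therefore does not carry from one of these cores to the other, but the gap is only a lower bound because compound 3 is at a limit of the assay and not a number, and the four compounds do not show why the two places interact: the limit of > 200 ug/mL in this assay, at which 1 of the 4 values shown sits.

Open, from the compounds shown here alone, is whether an ethyl group or a longer chain on that nitrogen follows the step seen on the core of compound 2 or that on the core of compound 1. Also open, going by these compounds, is how an amine or a carboxylic acid in place of cyano would behave on either core.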